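The source may hold more compounds than are shown below. What is called first, only, known or untested is meant among the compounds shown, and "the series" means these compounds.

Measured compounds:
compound 1, `O=C(Nc1ccc(-c2cnc3cc(N4CCN(C5CC5)CC4)ccn23)cc1)c1ccc([N+](=O)[O-])o1` — in a functional assay on MGC-803 cells (Homo sapiens) for antiproliferative activity, read by CCK-8 assay, with a stated time of 72 h (on this read-out lower numbers stand for stronger inhibition and higher numbers for weaker inhibition), compound 1 gives 1650 nM
compound 2, `O=C(Nc1ccc(-c2cnc3cc(N4CCCC4)ccn23)cc1)c1ccc([N+](=O)[O-])o1` — compound 2 gives 1150 nM
compound 3, `O=C(Nc1ccc(-c2cnc3cc(Br)ccn23)cc1)c1ccc([N+](=O)[O-])o1` — compound 3 gives 750 nM

Compound 3 carries the lowest of the three numbers. Its separation from compound 1 is a 2.2-fold lower number from compound 1 to compound 3 (0.34 log units; beyond the scatter), and from compound 2 it is a 1.5-fold lower number from compound 2 to compound 3 (0.19 log units; within the scatter), the latter within the scatter, so no order between compound 2 and compound 3 is claimed.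

Compound 4, `COc1ccn2c(-c3ccc(NC(=O)c4ccc([N+](=O)[O-])o4)cc3)cnc2c1`, differs from compound 3 by methoxy in place of bromo on an aromatic carbon. The measured steps that bear on this position are a 2.2-fold lower number from compound 1 to compound 3 (0.34 log units; beyond the scatter) and a 1.5-fold lower number from compound 2 to compound 3 (0.19 log units; within the scatter), both exchanges of a ring amine for bromo at the same carbon, and a 1.4-fold lower number from compound 1 to compound 2 (0.16 log units; within the scatter), an exchange of one ring amine for another. None of them involves methoxy, and two of the three lie within the scatter. Only a small step is therefore expected, estimated as a 1.3-fold higher number from compound 3 to compound 4 (0.10 log units; within the scatter) in this assay. The estimate for compound 4 is 950 nM, with a range of 400 nM to 2200 nM.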

Compound 4, half-maximal inhibitory concentration: 860 nM
Compound 4: middle estimate off by 1.1-fold (0.04 log units), on the high side, and the stated range covers the measured number.
By their numbers in this assay, from the lowest: compounds 3, 4, 2 and 1 (each within the scatter of the next, the first and the last beyond it).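

In this assay, the exchange of bromo for methoxy on this aromatic carbon, opposite the ring nitrogen, gives a 1.1-fold higher number from compound 3 to compound 4 (0.06 log units; within the scatter) and so adds an oxygen-linked group to the substituents seen at this position. Compared with the ring amines, the same position gives a 1.3-fold lower number from compound 2 to compound 4 (0.13 log units; within the scatter) and a 1.9-fold lower number from compound 1 to compound 4 (0.28 log units; within the scatter) for methoxy, so compound 4 cannot be placed in any order against compounds 1, 2 or 3, whereas bromo gave a 2.2-fold lower number from compound 1 to compound 3 (0.34 log units; beyond the scatter) against the 4-cyclopropylpiperazin-1-yl group. No available evidence accounts for how close these numbers lie.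

The compounds shown leave open whether a hydroxyl, a primary amine, a carboxylic acid or a longer alkoxy chain on this carbon would give numbers in the same range. They also leave open whether methoxy and bromo would stay this close with a change elsewhere on the shared core.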